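The source may report more compounds than this note shows. Statements on the series, on what has been measured and on what is new or still open speak of the compounds shown alone.

Measured in a functional assay on MCF7 cells (Homo sapiens) for antiproliferative activity, read by MTT assay, with a stated time of 48 h; on this read-out lower numbers stand for stronger inhibition and higher numbers for weaker inhibition:
- Compound 1 `CCN(CC)Cc1ccc2c(c1O)-c1ccc(cc1O)CCc1ccc(O)c(c1)Oc1ccc(cc1)CC2`: 7590 nM
- Compound 2 `Oc1ccc2cc1Oc1ccc(cc1)CCc1ccc(CN3CCCCC3)c(O)c1-c1ccc(cc1O)CC2`: 5070 nM
- Compound 3 `COc1ccc(N2CCN(Cc3ccc4c(c3O)-c3ccc(cc3O)CCc3ccc(O)c(c3)Oc3ccc(cc3)CC4)CC2)cc1`: > 20000 nM (a limit, not a number)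

Compound 3 has no number, only (the limit of > 20000 nM in this assay, at which 1 of the 3 values shown sits). Compound 4 `CC(C)(C)OC(=O)N1CCN(Cc2ccc3c(c2O)-c2ccc(cc2O)CCc2ccc(O)c(c2)Oc2ccc(cc2)CC3)CC1` differs from compound 3 on an amine nitrogen in a ring, with tert-butoxycarbonyl in place of 4-methoxyphenyl on an amine nitrogen in a ring. This exact swap has not been measured. For the measured compounds named here, the one measured step is a 1.5-fold lower number from compound 1 to compound 2 (0.18 log units; within the scatter), for piperidin-1-yl in place of diethylamino, and it is only a loose guide. Compound 1 at 7590 nM and compound 2 at 5070 nM both lack 4-methoxyphenyl, so a modestly lower number is expected. A second limit remains possible for compound 4. For compound 4 the expected value is 12000 nM, with an estimated range of 5000 nM to 25000 nM. The expected change is an at least 1.6-fold lower number from compound 3 to compound 4 (0.22 log units; that floor lies within the scatter).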

Compound 4, half-maximal inhibitory concentration: > 20000 nM
Compound 4: no number, only a limit; the forecaster's own chance of this, stated with the estimate: 35%; at least 1.6-fold (0.22 log units) between middle value and limit.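

No step can be read from compound 3 to compound 4, because both stand only as limits, not as numbers: the limit of > 20000 nM in this assay, at which 2 of the 4 values shown sit. Going by these compounds, how tert-butoxycarbonyl and 4-methoxyphenyl truly compare on this ring nitrogen stays open.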